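Adding a hydroxy group to compound 2

The source may hold more compounds than are shown below. What is called first, only, known or untested is meant among the compounds shown, and "the series" means these compounds.

Of the compounds shown here, three with a shared core have been measured in a functional assay on MGC-803 cells (Homo sapiens) for inhibition, read by CCK-8 assay, with a stated time of 48 h; a lower number here means a stronger inhibitor, a higher number a weaker inhibitor. Compound 1 `COc1ccc(CN(C(=O)CSc2nc3ccccc3o2)c2cc(OC)c(OC)c(OC)c2)cc1` gives 450 nM, compound 2 `CCN1CCN(C(=S)SCC(=O)N(Cc2ccc(OC)cc2)c2cc(OC)c(OC)c(OC)c2)CC1` gives 9890 nM, and compound 3 `COc1ccc(CN(C(=O)CSC(=S)N2CCc3ccccc32)c2cc(OC)c(OC)c(OC)c2)cc1` gives 8410 nM. Compound 2 therefore stands at the high end of these numbers, but not alone: a 1.2-fold lower number from compound 2 to compound 3 (0.07 log units; within the scatter) leaves it level with its nearest neighbour. The distance to the low end is much greater, shown by a 22-fold higher number from compound 1 to compound 2 (1.34 log units; beyond the scatter) and matched by a 19-fold higher number from compound 1 to compound 3 (1.27 log units; beyond the scatter).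

Compound 4 `CCN1CCN(C(=S)SCC(=O)N(Cc2ccc(OC)c(O)c2)c2cc(OC)c(OC)c(OC)c2)CC1` keeps everything in compound 2 except for one change, (hydroxy in place of hydrogen on an aromatic carbon). This turns 4-methoxybenzyl into 3-hydroxy-4-methoxybenzyl. Among the measured compounds shown here, none of the measured steps bears directly on this change, since all three alter the group on the sulfur and leave the 4-methoxybenzyl group untouched. The two large steps show what replacing that whole group can do, but they say nothing about a hydroxy in place of hydrogen on an aromatic carbon. For the measured compounds named here, with no measured precedent, no step beyond the scatter is expected in this assay, and the direction remains open. The expected change is a 1.6-fold lower number from compound 2 to compound 4 (0.22 log units; within the scatter). Compound 4 is estimated at 6000 nM, with an expected range from 1500 nM to 13000 nM.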

Compound 4, half-maximal inhibitory concentration: 380 nM
For compound 4 the middle estimate is 16-fold (1.20 log units) above the measured one; measured number outside the range, below it.
By their numbers in this assay, from the lowest: compounds 4 and 1 (each within the scatter of the next); then compounds 3 and 2 (each within the scatter of the next).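

In this assay the 4-methoxybenzyl group proves not to be a silent part of compound 2: hydroxy in place of hydrogen on an aromatic carbon, ortho to a methoxy group, gives a large step on its own (a 26-fold lower number from compound 2 to compound 4 (1.42 log units; beyond the scatter)). The earlier steps shown here all altered the group on the sulfur, replacing a whole group each time (a 22-fold higher number from compound 1 to compound 2 (1.34 log units; beyond the scatter) and a 19-fold higher number from compound 1 to compound 3 (1.27 log units; beyond the scatter)), whereas this change adds one oxygen atom at a different site, so the aromatic ring of the 4-methoxybenzyl group is now a second place where the number responds strongly. No measurement at hand explains why this single change has so large an effect.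

As far as these compounds go, it remains open whether an amine or a fluorine atom at the same place on the ring would give a step of similar size, or whether the hydroxy is specifically required. Also open, from the compounds shown here alone, is whether 3-hydroxy-4-methoxybenzyl would move the number in the same way with the group on the sulfur of compound 1 or compound 3 in place of the 4-ethylpiperazine-bearing group of compound 4.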